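The source may hold more compounds than are shown below. What is called first, only, known or untested is meant among the compounds shown, and "the series" means these compounds.

Two members of one small series have been measured in a functional assay on M14 cells (Homo sapiens) for inhibition, read by sulforhodamine B assay, with a stated time of 48 h; a higher number here means a weaker inhibitor of growth, a lower number a stronger inhibitor of growth. Compound 1 `COc1ccc(-c2cc(/C=C/C(=O)c3ccc(N)cc3)[nH]n2)cc1` gives 6540 nM in this assay. Compound 2 `COc1cc(-c2cc(/C=C/C(=O)c3ccc(N)cc3)[nH]n2)cc(OC)c1OC` gives 3860 nM in this assay. Compound 2 stands with the lowest of the two numbers, and the nearest to it is compound 1, whose number is higher by an amount that lies within the scatter of repeated measurements; the two values therefore cannot be ordered against each other.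

The next step leads from compound 2 to compound 3 `COc1ccc(C(=O)/C=C/c2cc(-c3cc(OC)c(OC)c(OC)c3)n[nH]2)cc1`, which has not yet been measured. The change is methoxy in place of amino on an aromatic carbon. For the measured compounds named here, no step between two measured compounds shows what this exchange does, so nothing so far anchors its size or direction. The account therefore rests on compound 2 alone. The step from compound 2 to compound 3 in this assay is expected to be a 1.3-fold higher number from compound 2 to compound 3 (0.11 log units; within the scatter), which is to say no more than the scatter of the assay, with a slight lean toward a higher number. Compound 3 is estimated at 5000 nM in this assay, within a range from 2000 nM to 12500 nM.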

Compound 3, concentration for total growth inhibition: 4930 nM
Beside the measured number, compound 3's estimate is 1.0-fold (0.01 log units) above it, within the range that was stated.
By their numbers in this assay, from the lowest: compounds 2, 3 and 1 (each within the scatter of the next).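

For the compounds shown here, the exchange of 4-aminophenyl for 4-methoxyphenyl is the first change at this place, on an aromatic carbon para to a large group, and in this assay it gives a 1.3-fold higher number from compound 2 to compound 3 (0.11 log units; within the scatter) in a single pair. Amino, which counts one hydrogen-bond donor, gives way to methoxy, which counts none, and the step does not rise above the scatter of the assay. On this core, then, the amino group is not shown to be required for a number in this range, although one pair cannot establish this for the series, and no measurement at hand bears on why the number stays within the scatter.

The compounds shown leave open whether a different group at this place, such as a hydroxyl, a dimethylamino group, a fluorine or a carboxylic acid, would carry the number beyond the scatter in either direction. They also leave open whether the same exchange of amino for methoxy would read alike on the core of compound 1, where the other aromatic ring carries a single methoxy group.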